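Compound 4: a 2-chlorophenyl swap at a modest step

The source may report more compounds than this note shows. Statements on the series, on what has been measured and on what is new or still open speak of the compounds shown alone.

Measured so far in a functional assay on MCF7 cells (Homo sapiens) for cytotoxicity, read by ELISA, with a stated time of 4 days; a higher number here means a weaker inhibitor, a lower number a stronger inhibitor:
compound 1 `Cc1ccsc1-c1cc(-c2ccoc2)cc(-c2ccco2)n1` gives 18300 nM
compound 2 `Cc1ccc(-c2cc(-c3ccoc3)cc(-c3ccc(Cl)s3)n2)o1` gives 1900 nM
compound 3 `Cc1cccc(-c2cc(-c3ccoc3)cc(-c3ccc(Cl)s3)n2)c1` gives 3990 nM

Among the measured compounds shown here, of these three numbers, the one for compound 3 is the second highest. Its nearest neighbour is compound 2, and the measured 2.1-fold higher number from compound 2 to compound 3 (0.32 log units; beyond the scatter) is a modest change, just beyond the scatter. For the measured compounds named here, compound 1 lies furthest away, with a clearly higher number than compound 3, but it differs from the others in more than one place and so offers no single step to compare.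

The next compound is compound 4 `Clc1ccc(-c2cc(-c3ccoc3)cc(-c3ccccc3Cl)n2)s1`, which has 2-chlorophenyl in place of 3-methylphenyl on an aromatic carbon, next to the ring nitrogen (2-chlorophenyl in place of 3-methylphenyl on an aromatic carbon), while the 5-chlorothiophen-2-yl and furan-3-yl groups stay as they are. Going by the values given here, only one measured step bears on this place, the modest 2.1-fold higher number from compound 2 to compound 3 (0.32 log units; beyond the scatter), and it exchanges a different pair of groups. It gives no direction for the present swap, so no step beyond the scatter is expected in this assay. The estimated step is a 1.1-fold lower number from compound 3 to compound 4 (0.06 log units; within the scatter), which lies within the scatter. For compound 4 the estimate is 3500 nM, with an expected range from 1500 nM to 8000 nM.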

Compound 4, half-maximal inhibitory concentration: 7360 nM
For compound 4 the middle estimate is 2.1-fold (0.32 log units) below the measured one, within the range that was stated.
By their numbers in this assay, from the lowest: compound 2; then compounds 3 and 4 (each within the scatter of the next); then compound 1.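

In this assay, putting 2-chlorophenyl in place of 3-methylphenyl on the aromatic carbon next to the ring nitrogen gives a 1.8-fold higher number from compound 3 to compound 4 (0.27 log units; within the scatter), so this position does not separate these two phenyl groups. The 5-methylfuran-2-yl group of compound 2 is separated from 2-chlorophenyl, with a 3.9-fold higher number from compound 2 to compound 4 (0.59 log units; beyond the scatter), and from 3-methylphenyl, with a 2.1-fold higher number from compound 2 to compound 3 (0.32 log units; beyond the scatter), so among compounds 2, 3 and 4 the furan-bearing compound gives the lowest number, and both phenyl groups stand apart from it by a modest margin. Nothing measured here bears on what lies behind these steps.

The compounds shown leave open whether the place of the chlorine on the phenyl ring matters, as a 4-chlorophenyl group would show, and whether the unsubstituted phenyl group would fall with the two phenyl groups seen here. Among the compounds shown here, they also leave open how a non-aromatic group at this carbon, such as an amine or a carboxylic acid, would read in this assay, since every group compared at this place so far is a single aromatic ring.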